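The compounds below may be only part of what the source reports. "The series", "measured", "known", "first", "only" and "open" are said of these compounds alone.

Three compounds share one core and differ only in the aromatic group attached to a carbon that is double-bonded to nitrogen. Compound 1 `CN(C)CCn1cnnc1-c1cc(Oc2ccc(NC(=O)N/N=C/c3c(O)ccc4ccccc34)cc2F)ccn1` carries a 2-hydroxynaphthalen-1-yl group there and in a functional assay on HT-29 cells (Homo sapiens) for cytotoxicity, read by MTT assay, with a stated time of 72 h (on this read-out lower numbers stand for stronger inhibition and higher numbers for weaker inhibition), compound 1 gives 670 nM. Compound 2 `COc1ccc(/C=N/NC(=O)Nc2ccc(Oc3ccnc(-c4nncn4CCN(C)C)c3)c(F)c2)cc1O` carries a 3-hydroxy-4-methoxyphenyl group, and in this assay compound 2 gives 960 nM. Compound 3 `CN(C)CCn1cnnc1-c1cc(Oc2ccc(NC(=O)N/N=C/c3ccc(F)cc3F)cc2F)ccn1` carries a 2,4-difluorophenyl group, and in this assay compound 3 gives 960 nM. The steps among them are small: a 1.4-fold higher number from compound 1 to compound 2 (0.16 log units; within the scatter), a 1.4-fold higher number from compound 1 to compound 3 (0.16 log units; within the scatter) and no change at the digits printed from compound 2 to compound 3 (within the scatter). Compound 3 thus stands level with compound 2, and it lies within the scatter of compound 1 as well, so none of the three can be set apart from the others.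

Compound 4 `COc1cc(/C=N/NC(=O)Nc2ccc(Oc3ccnc(-c4nncn4CCN(C)C)c3)c(F)c2)cc(OC)c1OC` continues the same pattern of exchange: 3,4,5-trimethoxyphenyl in place of 2,4-difluorophenyl on a carbon with a double bond to nitrogen. The three steps already seen, each exchanging this aromatic group for a quite different one, all stayed within the scatter, which suggests that the group at this carbon matters little in this assay. The step of a 1.0-fold higher number from compound 3 to compound 4 (0.02 log units; within the scatter) is therefore expected to stay within the scatter. Compound 4 is estimated at 1000 nM in this assay, within a range from 400 nM to 2500 nM.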

Compound 4, half-maximal inhibitory concentration: 3620 nM
Estimate against measurement, compound 4: 3.6-fold (0.56 log units) below; measured number above the stated range.
By their numbers in this assay, from the lowest: compounds 1, 2 and 3 (each within the scatter of the next); then compound 4.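

The group on the carbon with a double bond to nitrogen is not as indifferent in this assay as the first three compounds suggested: 3,4,5-trimethoxyphenyl in place of 2,4-difluorophenyl gives a 3.8-fold higher number from compound 3 to compound 4 (0.58 log units; beyond the scatter) and so weakens inhibition beyond the scatter. The same holds against the two other groups, with a 3.8-fold higher number from compound 2 to compound 4 (0.58 log units; beyond the scatter) and a 5.4-fold higher number from compound 1 to compound 4 (0.73 log units; beyond the scatter) so that compound 4 stands apart from a set of three quite different groups that could not be told apart. Compound 2 also carries a methoxy group and stays within the scatter of compound 3, so a single methoxy group on the ring does not by itself go with the weaker result, and nothing measured here accounts for the loss seen with compound 4.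

The compounds shown leave open whether all three methoxy groups are needed for this loss, or whether a dimethoxyphenyl group would already bring it. They also leave open how an amine or a carboxylic acid on this ring would behave in this assay.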